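Methoxy in place of hydrogen on the arylpiperazine ring

The compounds below may be only part of what the source reports. "The series", "measured", "known", "first", "only" and "open" are said of these compounds alone.

Of the compounds shown here, three sharing one core have been measured in an assay on CHO cells for displacement of a labelled ligand from 5-hydroxytryptamine receptor 7 (Homo sapiens); on this read-out lower numbers stand for stronger inhibition and higher numbers for weaker inhibition. Compound 1 `CCC1(CCCCN2CCN(c3cccc(Cl)c3)CC2)C(=O)Nc2ccccc21` gives 0.41 nM in this assay. Compound 2 `CCC1(CCCCN2CCN(c3ccc(Cl)cc3)CC2)C(=O)Nc2ccccc21` gives 0.38 nM; 0.38 nM (2 entries) in this assay. Compound 3 `CCC1(CCCCN2CCN(c3ccccc3)CC2)C(=O)Nc2ccccc21` gives 2.07 nM in this assay, the highest of the two single numbers, with compound 1 as its nearest neighbour; the step of a 5.0-fold higher number from compound 1 to compound 3 (0.70 log units; beyond the scatter) arises from hydrogen in place of chloro on an aromatic carbon.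

Compound 4 `CCC1(CCCCN2CCN(c3ccccc3OC)CC2)C(=O)Nc2ccccc21` has not yet been measured. It differs from compound 3 by methoxy in place of hydrogen on an aromatic carbon, on an aromatic carbon of a six-membered aromatic ring of carbon only, ortho to a large group. Within the data shown here, the only measured step touching this ring, a 5.0-fold higher number from compound 1 to compound 3 (0.70 log units; beyond the scatter), shows that removing a substituent from it raised the number by a modest amount. Among the measured compounds shown here, a substituent entering the ring is therefore expected to move the number in this assay downward by a modest amount, though a methoxy group is not a chloro group and no direct precedent exists here. For compound 4 the estimate is 0.8 nM, expected between 0.3 nM and 2.5 nM. This estimate means an expected step of a 2.6-fold lower number from compound 3 to compound 4 (0.41 log units; beyond the scatter).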

Compound 4, inhibition constant: 5.38 nM
The estimate for compound 4 lay 6.7-fold (0.83 log units) below the measured number; measured number outside the range, above it.
By their numbers in this assay, from the lowest: compound 1; then compound 3; then compound 4.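

In this assay, a substituent entering this ring did not by itself lower the number: methoxy on an aromatic carbon, ortho to a large group, gave a 2.6-fold higher number from compound 3 to compound 4 (0.41 log units; beyond the scatter) and so moved opposite to the effect of chloro seen earlier. Set against 3-chlorophenyl, the 2-methoxyphenyl group gave a 13-fold higher number from compound 1 to compound 4 (1.12 log units; beyond the scatter) and this large gap shows that the gain seen with chloro does not extend to every substituent on this ring. No supporting evidence bears on why the step went upward.

The compounds shown leave open whether the rise belongs to methoxy or to this place on the ring, as methoxy appears at no other ring carbon and chloro does not appear at this one. As far as these compounds go, how an ethoxy or hydroxy group would behave at this place also remains unknown.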